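The compounds below may be only part of what the source reports. "The series", "measured", "known", "first", "only" and "open" are said of these compounds alone.

Compound 1 `COC(=O)c1sc2cc(OC)ccc2c1Nc1cc(OC)c(OC)c(OC)c1`: 10.3 nM
Compound 2 `CCOC(=O)c1sc2ccccc2c1Nc1cc(OC)c(OC)c(OC)c1`: 1900 nM
Compound 3 `COC(=O)c1sc2nc(C)ccc2c1Nc1cc(OC)c(OC)c(OC)c1`: 0.5 nM

These values come from a functional assay on SEM cells (Homo sapiens) for cytotoxicity, read by MTT assay, with a stated time of 72 h; a lower number here means a stronger inhibitor, a higher number a weaker inhibitor. Compound 2 stands highest of the three and is the weakest inhibitor at 1900 nM, well beyond the scatter from both compound 1 and compound 3.

Compound 4 `CCOC(=O)c1sc2cccc(C)c2c1Nc1cc(OC)c(OC)c(OC)c1` has not yet been measured in this assay. It departs from compound 2 by methyl in place of hydrogen on an aromatic carbon, with methyl in place of hydrogen on an aromatic carbon. Going by the values given here, no two measured compounds here differ in only one place, so this change has no direct precedent. Compound 1 and compound 3 each differ from compound 2 in more than one place, and their far lower numbers cannot be assigned to any single change. A step beyond the scatter is therefore not expected, though there is a slight lean toward a lower number. The estimated change is a 1.9-fold lower number from compound 2 to compound 4 (0.28 log units; within the scatter). Compound 4 is expected at 1000 nM, with an estimated range of 200 nM to 4000 nM.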

Compound 4, half-maximal inhibitory concentration: 1930 nM
Beside the measured number, compound 4's estimate is 1.9-fold (0.29 log units) below it; low and high end bracket the measured number.
By their numbers in this assay, from the lowest: compound 3; then compound 1; then compounds 2 and 4 (each within the scatter of the next).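

In this assay, going by these compounds alone, the first pair of compounds that differ in only one place gives a 1.0-fold higher number from compound 2 to compound 4 (0.01 log units; within the scatter), with methyl in place of hydrogen on an aromatic carbon, ortho to a fused ring and meta to a fused ring. Within the data shown here, at this position on the core of compound 2, the added methyl therefore leaves the number within the scatter, a reading that the earlier compounds, which differ in more than one place, could not give. Nothing measured here accounts for this result.

Going by these compounds, it remains open whether an amine, a chlorine atom or a longer chain at the same position would move the number beyond the scatter. On these data alone, it also remains open whether methyl would behave in the same way at other positions of this ring or on the core of compound 1.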